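Chalcone amine series: benzyl variation at the amine

A few compounds are considered here, and "the series" means these few. Any claim that something is new, unique, unknown or untested is made for them only; others in the source may bear on it.

Of the compounds shown here, two carry numbers so far. Compound 1 `CCN(CCCCCCOc1ccc(C(=O)/C=C/c2ccc(N(C)C)cc2)c(O)c1)Cc1ccccc1` gives 31600 nM in an assay on isolated protein for inhibition of Amine oxidase [flavin-containing] A (Homo sapiens); on this read-out lower numbers stand for stronger inhibition and higher numbers for weaker inhibition; compound 2 `CCN(CCCCOc1ccc(C(=O)/C=C/c2ccc(N(C)C)cc2)c(O)c1)Cc1ccc(N(C)C)cc1` gives 17200 nM. Compound 2 holds the lowest of the two numbers, though its gap to compound 1 lies within the scatter and so marks no real separation. Compound 3 `CCN(CCCCOc1ccc(C(=O)/C=C/c2ccc(N(C)C)cc2)c(O)c1)Cc1ccccc1OC` is not yet measured; it differs from compound 2 by 2-methoxyphenyl in place of 4-(dimethylamino)phenyl on a saturated chain carbon bound to an amine nitrogen. For the measured compounds named here, with no single-change step among the measured compounds to lean on, the expected movement is small: the step of a 1.2-fold higher number from compound 2 to compound 3 (0.07 log units; within the scatter) is estimated to stay within the scatter, in no firm direction. Compound 3 is expected at 20000 nM, within 7000 nM to 60000 nM.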

Compound 3, half-maximal inhibitory concentration: 27500 nM
Estimate against measurement, compound 3: 1.4-fold (0.14 log units) below, and the stated range covers the measured number.
By their numbers in this assay, from the lowest: compounds 2, 3 and 1 (each within the scatter of the next).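

In this assay, 2-methoxyphenyl in place of 4-(dimethylamino)phenyl on a saturated chain carbon bound to an amine nitrogen gives a 1.6-fold higher number from compound 2 to compound 3 (0.20 log units; within the scatter) and so stays within the scatter: at this position, these two aromatic groups are not separated. The step of a 1.1-fold lower number from compound 1 to compound 3 (0.06 log units; within the scatter) also stays within the scatter, leaving all three compounds unseparated. No measurement here bears on the cause of these results.

Still open, on these data alone, is whether a carboxylic acid on the benzyl group would give a separation beyond the scatter. As far as these compounds go, the effect of a longer chain on the 2-methoxybenzyl amine also remains open.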